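Swapping a propyl for a furan on an acylthiourea

This account rests on a few compounds, and the source may have more. Where it says the series, first, only, none or still open, it means among the compounds named here.

Measured compounds in an ADME assay on Huh-7 cells (Homo sapiens) for cytotoxicity; on this read-out higher numbers stand for lower toxicity in this test and lower numbers for higher toxicity in this test:
- Compound 1, `NC(=S)N1CCc2c(OCCCCCOc3ccc(Cl)cc3)cccc21`: in this assay compound 1 gives > 50000 nM, which is a limit of the test rather than a number.
- Compound 2, `O=C(NC(=S)N1CCc2c(OCCCCCOc3ccc(Cl)cc3)cccc21)c1ccc(F)cc1`: compound 2 gives 31100 nM.
- Compound 3, `CCCC(=O)NC(=S)N1CCc2c(OCCCCCOc3ccc(Cl)cc3)cccc21`: compound 3 gives > 50000 nM, again a limit of the test.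

Compound 3 therefore has no exact number; it sits at the limit of > 50000 nM in this assay, at which 2 of the 3 values shown sit. The step from its parent reads as a step that the two limits leave unreadable from compound 1 to compound 3, and against the aryl analogue it reads as an at least 1.6-fold higher number from compound 2 to compound 3 (0.20 log units; that floor lies within the scatter), a floor that stays within the scatter. Compound 4, `O=C(NC(=S)N1CCc2c(OCCCCCOc3ccc(Cl)cc3)cccc21)c1ccco1`, is built from compound 3 by furan-2-yl in place of propyl on a carbonyl carbon. The measured steps that speak to this change are an at least 1.6-fold lower number from compound 1 to compound 2 (0.20 log units; that floor lies within the scatter) and an at least 1.6-fold higher number from compound 2 to compound 3 (0.20 log units; that floor lies within the scatter), both small and both inside the scatter, so an aromatic acyl group in place of an alkyl one has so far moved the read-out little. No step beyond the scatter is expected in this assay. Compound 4 is therefore expected to give about 40000 nM, between 15000 nM and 50000 nM. That expectation corresponds to a step of an at least 1.2-fold lower number from compound 3 to compound 4 (0.09 log units; that floor lies within the scatter).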

Compound 4, half-maximal cytotoxic concentration: 4620 nM
The estimate for compound 4 lay 8.7-fold (0.94 log units) above the measured number; measured number below the stated range.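

In this assay, going by these compounds alone, the group on this carbonyl carbon now clearly matters: furan-2-yl in place of propyl gives an at least 10-fold lower number from compound 3 to compound 4 (1.03 log units; beyond the scatter), the first step here that lies beyond the scatter. An aromatic ring alone does not explain this, as compound 2 also carries one on this carbonyl carbon, and the exchange of its 4-fluorophenyl for furan-2-yl gives a 6.7-fold lower number from compound 2 to compound 4 (0.83 log units; beyond the scatter), so the identity of the ring makes a difference in this series. Adding the (furan-2-yl)carbonyl group to the amide-type nitrogen of the parent gives an at least 10-fold lower number from compound 1 to compound 4 (1.03 log units; beyond the scatter), but this step and the one from the propyl compound are only floors, as their starting compounds have no exact number: the limit of > 50000 nM in this assay, at which 2 of the 4 values shown sit.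

The compounds shown leave open whether this step follows from the oxygen of the furan ring or from the five-membered aromatic ring as such. A thiophene ring, with sulfur in place of that oxygen, or an unsubstituted phenyl group, or a saturated tetrahydrofuran ring on the same carbonyl carbon would help to separate these possibilities.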